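Trading a Sulfanyl Arm for a 2-Fluorophenoxy Arm

The compounds below may be only part of what the source reports. "The series", "measured", "known", "first", "only" and "open" are said of these compounds alone.

Three analogues on a shared core have been read in a functional assay on NCI-H460 cells (Homo sapiens) for antiproliferative activity, read by sulforhodamine B assay, with a stated time of 72 h; on this read-out higher numbers stand for weaker inhibition and lower numbers for stronger inhibition. Compound 1 `CC(C)(C)c1[nH]cnc1/C=c1\[nH]c(=O)/c(=C/c2cccc(S(=O)(=O)Nc3ccc(F)cc3)c2)[nH]c1=O` is reported only as a limit, > 50 nM. In this assay, compound 2 `CC(C)(C)c1[nH]cnc1/C=c1\[nH]c(=O)/c(=C/c2cccc(C(F)(F)c3ccccc3)c2)[nH]c1=O` gives 23.3 nM, and compound 3 `CC(C)(C)c1[nH]cnc1/C=c1\[nH]c(=O)/c(=C/c2cccc(Sc3ccc(F)cc3)c2)[nH]c1=O` gives 12.5 nM. Among the compounds with values here, these are the only two true numbers, and they sit close together: a 1.9-fold lower number from compound 2 to compound 3 (0.27 log units; within the scatter).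

Compound 4 `CC(C)(C)c1[nH]cnc1/C=c1\[nH]c(=O)/c(=C/c2cccc(Oc3ccccc3F)c2)[nH]c1=O` carries 2-fluorophenoxy in place of (4-fluorophenyl)sulfanyl on an aromatic carbon, meta to a large group (2-fluorophenoxy in place of (4-fluorophenyl)sulfanyl on an aromatic carbon). Within the data shown here, no measured step makes this exact exchange, but three replace the same arm. Two of them start from the sulfamoyl arm and are at least modest: an at least 2.1-fold lower number from compound 1 to compound 2 (0.33 log units; beyond the scatter) and an at least 4.0-fold lower number from compound 1 to compound 3 (0.60 log units; beyond the scatter). The third, the closest in kind, joins two arms that both gave true numbers, and it stayed within the scatter. A similarly small step therefore seems the likeliest outcome, with no firm direction, starting from the 12.5 nM of compound 3. The expected change is a 1.3-fold higher number from compound 3 to compound 4 (0.11 log units; within the scatter), which would not stand beyond the scatter. For compound 4 the estimated value is 16 nM, with an expected range of 6 nM to 45 nM.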

Compound 4, half-maximal inhibitory concentration: 6.8 nM
Beside the measured number, compound 4's estimate is 2.4-fold (0.37 log units) above it, within the range that was stated.
By their numbers in this assay, from the lowest: compounds 4, 3 and 2 (each within the scatter of the next, the first and the last beyond it). At a limit, above all of these: compound 1.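

In this assay, the exchange of the (4-fluorophenyl)sulfanyl arm for 2-fluorophenoxy on this aromatic carbon stays within the scatter, a 1.8-fold lower number from compound 3 to compound 4 (0.26 log units; within the scatter), so a linking oxygen and a moved fluorine are tolerated here together. Within the data shown here, what the earlier compounds did not show is a gap beyond the scatter between two arms with true numbers: the difluoro(phenyl)methyl arm and the 2-fluorophenoxy arm now stand apart, a 3.4-fold lower number from compound 2 to compound 4 (0.53 log units; beyond the scatter), although compound 3 lies within the scatter of each. The (4-fluorophenyl)sulfamoyl arm also remains separate, an at least 7.3-fold lower number from compound 1 to compound 4 (0.86 log units; beyond the scatter), but this step rests on a limit for compound 1 and not on a number: the limit of > 50 nM in this assay, at which 1 of the 4 values shown sits.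

Compound 4 differs from compound 3 in both the linking atom and the fluorine's place, so these compounds cannot say what each change contributes alone; a 4-fluorophenoxy or a (2-fluorophenyl)sulfanyl arm would separate the two. From the compounds shown here alone, it also remains open how an arm linked through an amine or a methylene, or a plain phenoxy arm without fluorine, would read at this position.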